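The compounds below may be only part of what the source reports. "The series", "measured", "known", "first", "only" and "open" are said of these compounds alone.

Measured so far:
Compound 1 `COc1cc2ncnc(N3CCc4ccccc43)c2cc1NC(=O)C=C(C)C` gives 7840 nM in a functional assay on PC-3 cells (Homo sapiens) for antiproliferative activity, read by MTT assay, with a stated time of 72 h; a lower number here means a stronger inhibitor, a higher number a weaker inhibitor.
Compound 2 `C/C=C/C(=O)Nc1cc2c(N3CCc4ccccc43)ncnc2cc1OC` gives 8120 nM in this assay.

Within the data shown here, compound 2 stands at the highest of the two numbers, with compound 1 nearest; the only step so far, a 1.0-fold higher number from compound 1 to compound 2 (0.02 log units; within the scatter), is within the scatter. Compound 3 `CC/C=C/C(=O)Nc1cc2c(N3CCc4ccccc43)ncnc2cc1OC` differs from compound 2 by methyl in place of hydrogen on a saturated chain carbon bound to a double-bonded chain carbon. Among the measured compounds shown here, the one step that bears on it, the shortening of the chain from compound 1 to compound 2, was flat, so no step beyond the scatter is expected in this assay. Compound 3 is estimated at 8000 nM, range 4000 nM to 16000 nM, meaning an expected step of a 1.0-fold lower number from compound 2 to compound 3 (0.01 log units; within the scatter).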

Compound 3, half-maximal inhibitory concentration: 5890 nM
Beside the measured number, compound 3's estimate is 1.4-fold (0.13 log units) above it; the range from low to high includes it.
By their numbers in this assay, from the lowest: compounds 3, 1 and 2 (each within the scatter of the next).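

The methyl on a saturated chain carbon bound to a double-bonded chain carbon gives a 1.4-fold lower number from compound 2 to compound 3 (0.14 log units; within the scatter) in this assay, and the exchange of one chain for the other on the carbonyl gives a 1.3-fold lower number from compound 1 to compound 3 (0.12 log units; within the scatter). Extending the chain to but-1-en-1-yl therefore separates compound 3 from neither compound 1 nor compound 2 in this series. No evidence bears on these numbers.

Open, on these data alone, is whether a longer chain, or a dimethylamino group on the chain, would produce a step beyond the scatter.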